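Series notes: quinolin-3-yl replacing hydroxyethylpiperidinyl at the aromatic carbon

A few compounds are considered here, and "the series" means these few. Any claim that something is new, unique, unknown or untested is made for them only; others in the source may bear on it.

Compound 1 `OCCC1CCN(c2nccnc2OC2CN(c3ccc4ccccc4n3)C2)CC1` stands second highest of three in a physicochemical assay for solubility, in phosphate buffer, at pH 7.4 (a higher number here means a more soluble compound, a lower number a less soluble compound), and gives 84000 nM; compound 3 `c1ccc2nc(N3CC(Oc4nccnc4-c4ccncc4)C3)ccc2c1` gives 56000 nM, while compound 2 `c1ccc(-c2nccnc2OC2CN(c3ccc4ccccc4n3)C2)nc1` gives 349000 nM. Compound 4 `c1ccc2ncc(-c3nccnc3OC3CN(c4ccc5ccccc5n4)C3)cc2c1` differs from compound 1 by quinolin-3-yl in place of 4-(2-hydroxyethyl)piperidin-1-yl on an aromatic carbon. Among the compounds with values here, the steps that bear on this are a 4.2-fold higher number from compound 1 to compound 2 (0.62 log units; beyond the scatter) and a 1.5-fold lower number from compound 1 to compound 3 (0.18 log units; within the scatter); the aromatic replacements went in both directions, and a 6.2-fold lower number from compound 2 to compound 3 (0.79 log units; beyond the scatter) shows the two pyridyl isomers are themselves far apart. The entering quinolin-3-yl is a larger aromatic group with one acceptor and no donor, a pattern nearer to compound 3 than to compound 2, so a modest downward step or none beyond the scatter is expected: a 2.8-fold lower number from compound 1 to compound 4 (0.45 log units; beyond the scatter). Compound 4 is estimated at 30000 nM, within 7000 nM to 130000 nM.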

Compound 4, solubility: < 1000 nM
Compound 4 was reported as a limit; the forecaster's own chance of this, stated with the estimate: 5%; middle value at least 30-fold (1.47 log units) from the limit.
By their numbers in this assay, from the lowest: compounds 3 and 1 (each within the scatter of the next); then compound 2. At a limit, below all of these: compound 4.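

In this assay compound 4 gives < 1000 nM, which is a limit and not a number. Quinolin-3-yl at this position gives an at least 84-fold lower number from compound 1 to compound 4 (1.92 log units; beyond the scatter), an at least 56-fold lower number from compound 3 to compound 4 (1.74 log units; beyond the scatter) and an at least 340-fold lower number from compound 2 to compound 4 (2.54 log units; beyond the scatter), so an aromatic replacement here can move the read-out much further than the earlier steps showed. Of the aromatic groups shown at this position, only quinolin-3-yl has a second aromatic ring, but a single compound cannot tie the step to that ring.

Going by these compounds, the true size of these steps remains open. So does whether a quinolin-3-yl carrying an amine or a carboxylic acid would give a value clear of the limit.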